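A Second Trifluoromethyl Group on the Aryl Ring

This account rests on a few compounds, and the source may have more. Where it says the series, first, only, none or still open, it means among the compounds named here.

Measured so far:
- compound 1, `CC(C)(N)C(=O)N[C@H](COCc1cccc(Cl)c1)c1nnnn1CCOC(=O)NCCCCO`: 1.6 nM
- compound 2, `CC(C)(N)C(=O)N[C@H](COCc1cccc(C(F)(F)F)c1)c1nnnn1CCOC(=O)NCCCCO`: 1.79 nM

Among the measured compounds shown here, in a functional assay on cells for inhibition of growth hormone secretagogue receptor type 1 (Homo sapiens), read by FLIPR and calcium flux (on this read-out lower numbers stand for an effect already at smaller amounts and higher numbers for an effect only at larger amounts of compound), compound 2 stands highest of the two numbers, although the only measured step, a 1.1-fold higher number from compound 1 to compound 2 (0.05 log units; within the scatter), lies within the scatter. Compound 3, `CC(C)(N)C(=O)N[C@H](COCc1cc(C(F)(F)F)cc(C(F)(F)F)c1)c1nnnn1CCOC(=O)NCCCCO`, differs from compound 2 by trifluoromethyl in place of hydrogen on an aromatic carbon. For the measured compounds named here, the one step that bears on this exchange swapped chloro for trifluoromethyl without a shift beyond the scatter; no measured step adds a second group to the ring, so the expectation for compound 3 rests on that single comparison. The step of a 1.4-fold higher number from compound 2 to compound 3 (0.15 log units; within the scatter) is expected to stay small. Compound 3 is estimated at 2.5 nM, within 0.9 nM to 7 nM.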

Compound 3, half-maximal effective concentration: 34 nM
Estimate against measurement, compound 3: 14-fold (1.13 log units) below, outside the stated range (above it).
By their numbers in this assay, from the lowest: compounds 1 and 2 (each within the scatter of the next); then compound 3.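

In this assay a second trifluoromethyl on the ring brings a 19-fold higher number from compound 2 to compound 3 (1.28 log units; beyond the scatter). Exchanging chloro for trifluoromethyl at the first ring position left the numbers within the scatter, but this other aromatic carbon, meta to a trifluoromethyl group, does not accept a trifluoromethyl in place of hydrogen without a large change. Nothing available here gives a cause for this step. The compounds shown leave open whether a fluorine atom, a methoxy group or an amine on the same carbon would bring a similar change.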